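Adding a Methoxy Group to a Phenyl Ring

The source may hold more compounds than are shown below. What is called first, only, known or untested is meant among the compounds shown, and "the series" means these compounds.

Compound 1 `Cc1cc(-c2ccccc2)c2ncc(CSCCc3ccccc3)n2c1` was tested in an ADME assay on HEL cells (Homo sapiens) for cytotoxicity, with a stated time of 3 days (on this read-out lower numbers stand for higher toxicity in this test and higher numbers for lower toxicity in this test), where compound 1 gives 20 ug/mL. The closest measured neighbour is compound 2 `Cc1cc(-c2ccccc2)cn2c(CSCCc3ccccc3)cnc12`, which in this assay gives 20 ug/mL, so compound 1 stands level with compound 2 at the digits shown, within the scatter of the test. Compound 3 `Cc1cc(-c2cccc([N+](=O)[O-])c2)cn2c(CSCCc3ccccc3)cnc12` in this assay gives >= 100 ug/mL, which is a limit of the assay and not a number. Among the measured compounds shown here, the one single-point change that has been measured is an at least 5.0-fold higher number from compound 2 to compound 3 (0.69 log units; beyond the scatter), and its size is set by the limit of >= 100 ug/mL in this assay, at which 1 of the 3 values shown sits.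

Compound 4 `COc1ccc(-c2cc(C)cn3c(CSCCc4ccccc4)cnc23)cc1` differs from compound 1 by methoxy in place of hydrogen on an aromatic carbon. For the measured compounds named here, no measured step adds a methoxy group, so the nitro step is the only guide, and it concerns a different group on the same kind of ring. A step toward a higher number in this assay is therefore possible, but a smaller one than was seen with the nitro group, or none beyond the scatter, is the more cautious expectation.

For compound 4 the expected value in this assay is 30 ug/mL, with a range from 15 ug/mL to 100 ug/mL. This expectation corresponds to a step of a 1.5-fold higher number from compound 1 to compound 4 (0.18 log units; within the scatter).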

Compound 4, minimum cytotoxic concentration: 20 ug/mL
For compound 4 the middle estimate is 1.5-fold (0.18 log units) above the measured one; measured number inside the range.
By their numbers in this assay, from the lowest: compounds 1, 2 and 4 (each within the scatter of the next). At a limit, above all of these: compound 3.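

In this assay, going from phenyl to 4-methoxyphenyl gives no change at the digits printed from compound 1 to compound 4 (within the scatter). So far the only measured single change on this phenyl ring was the nitro one, an at least 5.0-fold higher number from compound 2 to compound 3 (0.69 log units; beyond the scatter), and the methoxy group, placed para to a large group, shows that a new group on this ring does not always come with a higher number. Compound 3 gives >= 100 ug/mL, which is a limit of the assay and not a number, so the full size of the nitro step stays unknown: the limit of >= 100 ug/mL in this assay, at which 1 of the 4 values shown sits.

The compounds shown do not tell whether the gap between the nitro and methoxy steps comes from the group itself or from where it sits on the ring. They also leave open what an amine, a carboxylic acid or a longer chain such as ethoxy would do at this same position in this assay.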